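This account rests on a few compounds, and the source may have more. Where it says the series, first, only, none or still open, it means among the compounds named here.

Compound 1 `Nc1ccccc1NC(=O)c1ccc(Cn2cnc3c(Nc4ccc(-c5ccccn5)cc4)nc(Cl)nc32)cc1` is the starting point. In a functional assay on HepG2 cells (Homo sapiens) for antiproliferative activity, read by CCK-8 assay, with a stated time of 72 h, tested at 2 uM (on this read-out higher numbers stand for a stronger effect at the one concentration tested and lower numbers for a weaker effect), compound 1 gives 11.5%, the largest of the three numbers measured, though the gaps to the other two lie within the usual scatter. Compound 2 `Nc1ccccc1NC(=O)c1ccc(CNc2nc(Cl)nc3c2ncn3Cc2ccccc2)cc1` gives 5.01% in this assay, and compound 3 `CCCCn1cnc2c(NCc3ccc(C(=O)Nc4ccccc4N)cc3)nc(Cl)nc21` gives 6.8%. Among the measured compounds shown here, the only measured step, a number 1.8 percentage points higher from compound 2 to compound 3 (within the scatter), changes a group on a saturated chain carbon and does not move the number beyond the scatter.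

Compound 4 `Nc1ccccc1NC(=O)c1ccc(Cn2cnc3c(Nc4cccc(Cl)c4)nc(Cl)nc32)cc1` differs from compound 1 in one place: 3-chlorophenyl in place of 4-(pyridin-2-yl)phenyl on a nitrogen on an aromatic ring. For the measured compounds named here, no measured step touches this nitrogen on the aromatic ring, so nothing measured speaks directly to the change, and the one step that exists elsewhere was within the scatter. All three numbers sit low at the single concentration tested, and there is no basis for expecting compound 4 to leave that low range. Compound 4 is therefore expected to give about 9%, within 1% to 22%, which would mean a step of a number 2.5 percentage points lower from compound 1 to compound 4 (within the scatter) from compound 1, an expected change of no more than the scatter.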

Compound 4, a percentage reported as inhibition, at one concentration (the size of the read-out at that concentration, not a potency): 29.9%
Compound 4: middle estimate off by 20.9 percentage points, on the low side; the whole stated range lies below it.
By their numbers in this assay, from the lowest: compounds 2, 3 and 1 (each within the scatter of the next); then compound 4.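

Among the compounds shown here, on the nitrogen on an aromatic ring, 3-chlorophenyl in place of 4-(pyridin-2-yl)phenyl gives the only step in this assay that clears the scatter, a number 18.4 percentage points higher from compound 1 to compound 4 (beyond the scatter). Unlike the saturated chain carbon changed between compound 2 and compound 3, this position can therefore move the number, and in this one pair 3-chlorophenyl, the group with fewer heavy atoms, gives a higher number than 4-(pyridin-2-yl)phenyl. Nothing measured here explains why the number rises.

This single pair cannot separate the part played by the chlorine from that played by the loss of the pyridine ring. An unsubstituted phenyl on this nitrogen, or a methoxy group or an amine in place of the chlorine, would bear on that question, and a single-concentration read-out gives no potency for compound 4.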